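Ethynyl in place of 3-hydroxypropyl: a second instance

The source may report more compounds than this note shows. Statements on the series, on what has been measured and on what is new or still open speak of the compounds shown alone.

Compound 1 `Cc1cccc(Nc2nc(-c3ccncc3CCCO)cs2)c1` and compound 3 `Cc1cccc(Nc2nc(-c3ccnc(CCCO)c3)cs2)c1` are built from the same atoms joined differently; the difference between the two cores is not broken down here. In a functional assay on RCC4 cells (Homo sapiens) for inhibition, read by XTT assay, with a stated time of 4 days (a lower number here means a stronger inhibitor, a higher number a weaker inhibitor), compound 1 gives 6920 nM, and compound 3 gives 5250 nM; these two values lie within the scatter of each other, so no order between them is claimed. Compound 2 `C#Cc1cnccc1-c1csc(Nc2cccc(C)c2)n1` carries one change relative to compound 1, (ethynyl in place of 3-hydroxypropyl on an aromatic carbon), and in this assay compound 2 gives 1380 nM. Among the measured compounds shown here, the resulting step, a 5.0-fold lower number from compound 1 to compound 2 (0.70 log units; beyond the scatter), is beyond the scatter and is the only measured instance of this change in the set.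

Compound 4 `C#Cc1cc(-c2csc(Nc3cccc(C)c3)n2)ccn1` carries the same kind of change relative to compound 3, (ethynyl in place of 3-hydroxypropyl on an aromatic carbon). The place is not the same word for word: in compound 2 the ethynyl is ortho to a large group and two atoms from the ring nitrogen, whereas in compound 4 it is next to the ring nitrogen and meta to a large group. With a single precedent, the expectation for compound 4 rests on that one measured step alone. Allowing for the differing surroundings of the place, the expected step is set slightly below the measured one: compound 4 is expected to move by a 4.0-fold lower number from compound 3 to compound 4 (0.61 log units; beyond the scatter) in this assay. Compound 4 is accordingly estimated at 1300 nM in this assay, with a likely range from 500 nM to 3500 nM.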

Compound 4, half-maximal inhibitory concentration: 18200 nM
Compound 4: middle estimate off by 14-fold (1.15 log units), on the low side; measured number above the stated range.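

In this assay, ethynyl in place of 3-hydroxypropyl gives a 3.5-fold higher number from compound 3 to compound 4 (0.54 log units; beyond the scatter) and so the earlier step does not carry over from one core to the other in either size or direction: the same change on two cores in this assay, a 5.0-fold lower number (0.70 log units; beyond the scatter) from compound 1 to compound 2 and a 3.5-fold higher number (0.54 log units; beyond the scatter) from compound 3 to compound 4, 17-fold (1.24 log units) apart, beyond the scatter of two such steps

For this series, the result shows that a step measured on the core of compound 1 cannot be used on its own to set an expectation for the core of compound 3, even though the group that leaves and the group that enters are the same. It does not show which difference between the two pairs decides the direction, whether the place next to the ring nitrogen and meta to a large group in compound 4 or some other feature of the core, and two pairs cannot say which direction is the more usual one for this change.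

On these data alone, it remains open whether a longer chain, an amine or a carboxylic acid in place of 3-hydroxypropyl would follow the direction seen in compound 2 or that seen in compound 4. A further matched pair on each core would be needed to tell whether the two directions hold for other groups at these places.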